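Bromo in Place of Chloro on the Shared Core

The source may hold more compounds than are shown below. What is called first, only, known or untested is meant among the compounds shown, and "the series" means these compounds.

Of the compounds shown here, two built on a shared lactam-containing core have been measured in an assay on isolated protein for inhibition of Amine oxidase [flavin-containing] A (Homo sapiens), read by fluorescence and spectrophotometry, with a stated time of 20 min; on this read-out lower numbers stand for stronger inhibition and higher numbers for weaker inhibition. Compound 1 `O=C1CCc2ccc(OCc3cccc(Br)c3)cc2N1` gives 7980 nM in this assay. Compound 2 `O=C1CCc2cc(OCc3cccc(Cl)c3)ccc2N1` gives 50600 nM in this assay, the highest of the two numbers, and its distance from compound 1 lies beyond the scatter of repeated measurements. Compound 1 and compound 2 differ in more than one place at once, so their two values show only that gap and nothing about any single change.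

Compound 3 `O=C1CCc2cc(OCc3cccc(Br)c3)ccc2N1` has not yet been measured. It differs from compound 2 by bromo in place of chloro on an aromatic carbon. Within the data shown here, no pair of measured compounds differing in that one place exists here, so there is no measured guide for this exchange. Compound 3 is expected to land close to compound 2, with the step of a 1.4-fold lower number from compound 2 to compound 3 (0.16 log units; within the scatter) estimated to fall within the usual scatter, leaning if anything toward a lower number. The value of compound 3 in this assay is estimated at 35000 nM, within a range from 12000 nM to 100000 nM.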

Compound 3, half-maximal inhibitory concentration: 12400 nM
Estimate against measurement, compound 3: 2.8-fold (0.45 log units) above; low and high end bracket the measured number.
By their numbers in this assay, from the lowest: compounds 1 and 3 (each within the scatter of the next); then compound 2.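

In this assay, among these compounds, the exchange of chloro for bromo on this aromatic carbon, meta to a large group, gives the first reading of a single change on the shared core (a 4.1-fold lower number from compound 2 to compound 3 (0.61 log units; beyond the scatter)), a modest step beyond the scatter. This position therefore responds to which halogen it carries, although the two groups match in what is counted here: one heavy atom each, with no hydrogen-bond donors or acceptors. Nothing available explains the size or direction of this step.

The compounds shown leave open whether the same exchange would give a step of similar size on the core of compound 1. They also leave open how this position would answer to a methoxy group, a nitrile or an amine in place of the halogen.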